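Esterifying the Carboxylic Acid of a Chromene Scaffold

This account rests on a few compounds, and the source may have more. Where it says the series, first, only, none or still open, it means among the compounds named here.

Measured compounds:
compound 1, `O=C(O)C1=Cc2ccccc2OC1(OCc1cc(-c2ccc(F)cc2)no1)C(F)(F)F`: 64200 nM
compound 2, `CCOC(=O)C1=Cc2ccccc2OC1(OCc1cn(CC(=O)Nc2cccc(F)c2)nn1)C(F)(F)F`: > 150000 nM
compound 3, `O=C(O)C1=Cc2ccccc2OC1(OCc1cc(-c2ccc(F)cc2F)no1)C(F)(F)F`: > 150000 nM

Compound 1 is the only one of the three to return a number in a functional assay on MCF7 cells (Homo sapiens) for inhibition, read by MTT assay, with a stated time of 24 h; on this read-out lower numbers stand for stronger inhibition and higher numbers for weaker inhibition; the other two sit at a limit of the assay. Compound 2 is reported only as a limit, > 150000 nM. Compound 3 likewise is reported only as a limit, > 150000 nM. Going by the values given here, the single measured step runs between compound 1 and compound 3, a fluoro in place of hydrogen on an aromatic carbon, and gives an at least 2.3-fold higher number from compound 1 to compound 3 (0.36 log units; beyond the scatter). That step is bounded by the limit of > 150000 nM in this assay, at which 2 of the 3 values shown sit.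

Compound 4, `CCOC(=O)C1=Cc2ccccc2OC1(OCc1cc(-c2ccc(F)cc2)no1)C(F)(F)F`, is the compound not yet measured. It differs from compound 1 by ethyl in place of hydrogen on an oxygen next to a carbonyl group. Among the compounds with values here, no measured step covers this change: the step from compound 1 to compound 3 alters the aryl fluorine pattern and leaves the carboxylic acid untouched. Within the data shown here, the ethyl ester compound 2 shows only a limit in this assay, and it carries a different heteroaryl group, so no step to compound 4 is available from it. The estimate for compound 4 is therefore expected to lie near or above the weak number of compound 1, with a real chance of another limit. Compound 4 is expected to give 110000 nM (range 30000 nM to 300000 nM), which means an expected step of a 1.7-fold higher number from compound 1 to compound 4 (0.23 log units; within the scatter).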

Compound 4, half-maximal inhibitory concentration: 48200 nM
Estimate against measurement, compound 4: 2.3-fold (0.36 log units) above; measured number inside the range.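

In this assay, the exchange of carboxy for ethoxycarbonyl gives a 1.3-fold lower number from compound 1 to compound 4 (0.12 log units; within the scatter), which places the two values within the scatter of each other and shows that a free carboxylic acid is not needed for a measurable number on this core. The earlier measured step left this position untouched, and it alone could not show how the assay responds to a change on the oxygen next to a carbonyl group. Compound 4 is also the only ethyl ester shown that returns a number rather than a limit, although both it and compound 1 remain weak on this read-out.

The compounds shown leave open whether a methyl ester, a longer chain such as butyl, or a primary amide at this place would also stay within the scatter of compound 1, and whether the ethyl ester would behave the same way with the aryl fluorine pattern of compound 3. Any such comparison has little room to show a weaker result, and a further limit would give no exact step: the limit of > 150000 nM in this assay, at which 2 of the 4 values shown sit.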